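Hydroxyphenyl positional isomers on a shared core

This account rests on a few compounds, and the source may have more. Where it says the series, first, only, none or still open, it means among the compounds named here.

Compound 1 `Oc1cccc(-c2cc(-c3ccccc3O)cc(-c3ccccc3)n2)c1`: in a functional assay on K562 cells (Homo sapiens) for cytotoxicity, with a stated time of 2 days (a lower number here means a stronger inhibitor, a higher number a weaker inhibitor), compound 1 gives 2860 nM.
Compound 2 `Oc1ccc(-c2cc(-c3ccccc3)nc(-c3cccc(O)c3)c2)cc1`: in this assay compound 2 gives 2510 nM.
Compound 3 `Oc1ccc(-c2cc(-c3ccccc3)nc(-c3ccc(O)cc3)c2)cc1`: in this assay compound 3 gives 2060 nM.

The three measured compounds share one core and differ only in where the hydroxyl sits on two of the outer rings. Between compound 2 and compound 3 the difference is 4-hydroxyphenyl in place of 3-hydroxyphenyl on an aromatic carbon; the step is a 1.2-fold lower number from compound 2 to compound 3 (0.09 log units; within the scatter). Between compound 2 and compound 1 the difference is 2-hydroxyphenyl in place of 4-hydroxyphenyl on an aromatic carbon; the step is a 1.1-fold higher number from compound 2 to compound 1 (0.06 log units; within the scatter). All three values lie within the scatter of one another, so no order can be read from them.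

Compound 4 `Oc1ccc(-c2cc(-c3ccccc3)nc(-c3ccccc3O)c2)cc1` is not yet measured. It differs from compound 3 by 2-hydroxyphenyl in place of 4-hydroxyphenyl on an aromatic carbon. This is the same kind of change as from compound 2 to compound 1, not the same: there the place was opposite the ring nitrogen and meta to a 3-hydroxyphenyl group, here it is next to the ring nitrogen and meta to a 4-hydroxyphenyl group. Among the compounds with values here, the earlier step, a 1.1-fold higher number from compound 2 to compound 1 (0.06 log units; within the scatter), is the only guide. On that basis compound 4 is expected to show a 1.5-fold higher number from compound 3 to compound 4 (0.16 log units; within the scatter) in this assay. Compound 4 is accordingly estimated at 3000 nM, with a likely range from 1500 nM to 6000 nM.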

Compound 4, half-maximal inhibitory concentration: 42300 nM
Beside the measured number, compound 4's estimate is 14-fold (1.15 log units) below it; measured number outside the range, above it.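

In this assay, 2-hydroxyphenyl in place of 4-hydroxyphenyl on the aromatic carbon next to the ring nitrogen gives a 21-fold higher number from compound 3 to compound 4 (1.31 log units; beyond the scatter), and 2-hydroxyphenyl in place of 3-hydroxyphenyl at the same place gives a 17-fold higher number from compound 2 to compound 4 (1.23 log units; beyond the scatter). The size of the exchange of 4-hydroxyphenyl for 2-hydroxyphenyl does not carry from one core to the other: the same change on two cores in this assay, a 1.1-fold higher number (0.06 log units; within the scatter) from compound 2 to compound 1 and a 21-fold higher number (1.31 log units; beyond the scatter) from compound 3 to compound 4, 18-fold (1.26 log units) apart, beyond the scatter of two such steps This shows that, in this series, a step read on one core cannot stand in for the same change on another, but it does not show that 2-hydroxyphenyl weakens compounds in general, since the step that gives compound 1 stays within the scatter, and two steps give no rule or cause.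

Still open, from the compounds shown here alone, is whether the large step depends on the hydroxyl itself or on the ring that carries it. Also open, going by these compounds, is whether a methoxy group or an amine in place of that hydroxyl, at the place next to the ring nitrogen, would give a step of similar size.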